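Aryl sulfonate series: urea in place of chloroacetamide

A few compounds are considered here, and "the series" means these few. Any claim that something is new, unique, unknown or untested is made for them only; others in the source may bear on it.

Going by the values given here, compound 2 `O=C(CCl)Nc1ccc(S(=O)(=O)Oc2ccccc2I)cc1` sits level with compound 1 `CC(C)c1ccccc1OS(=O)(=O)c1ccc(NC(=O)CCl)cc1` on the numbers so far. In a functional assay on M21 cells (Homo sapiens) for antiproliferative activity, read by sulforhodamine B assay, with a stated time of 48 h (on this read-out lower numbers stand for stronger inhibition and higher numbers for weaker inhibition), compound 2 gives 3900 nM, and compound 1 gives 3900 nM; the step of no change at the digits printed from compound 1 to compound 2 (within the scatter) exchanges iodo for isopropyl on an aromatic carbon and leaves the read-out unmoved within the scatter. Compound 3 `O=C(Nc1ccc(S(=O)(=O)Oc2ccccc2I)cc1)NC1CC1` differs from compound 2 by cyclopropylamino in place of chloromethyl on a carbonyl carbon, on a carbonyl carbon whose other neighbour is the amide-type nitrogen; read one bond further out, (chloromethyl)carbonyl becomes cyclopropylcarbamoyl. Among the compounds with values here, no measured step touches this carbonyl substituent; the only step available, from compound 1 to compound 2, concerns the aromatic ring and offers no guide here. For compound 3 the expectation is therefore uncertain, with a step of a 3.1-fold higher number from compound 2 to compound 3 (0.49 log units; beyond the scatter) towards weaker inhibition allowed within a broad range. Compound 3 is estimated at 12000 nM, between 3000 nM and 50000 nM.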

Compound 3, half-maximal inhibitory concentration: 11000 nM
Beside the measured number, compound 3's estimate is 1.1-fold (0.04 log units) above it; the measured number falls inside the stated range.
By their numbers in this assay, from the lowest: compounds 1 and 2 (each within the scatter of the next); then compound 3.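

In this assay the carbonyl substituent responds where the change on the aromatic carbon did not: cyclopropylamino in place of chloromethyl on a carbonyl carbon gives a 2.8-fold higher number from compound 2 to compound 3 (0.45 log units; beyond the scatter) and so lies beyond the scatter, though it is modest in size. Chloromethyl is not needed for a measurable read-out: compound 3 gives 11000 nM without it, with cyclopropylamino on the same carbonyl carbon. Nothing at hand bears on the reason for this shift.

This single step does not separate the loss of chloromethyl from the entry of cyclopropylamino; a methyl, methylamino or dimethylamino group on the same carbonyl carbon would tell the two apart. From the compounds shown here alone, it also remains open whether iodo and isopropyl stay level once cyclopropylamino occupies the carbonyl carbon.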